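Swapping methoxy for trifluoromethyl in an inactive series

A few compounds are considered here, and "the series" means these few. Any claim that something is new, unique, unknown or untested is made for them only; others in the source may bear on it.

Three related compounds, compound 1 (`Cc1cccc(-c2nc3cc(C)ccc3c(=O)[nH]2)c1`), compound 2 (`Cc1ccc2nc(-c3cccc(OC(F)(F)F)c3)[nH]c(=O)c2c1`) and compound 3 (`COc1cccc(-c2nc3cc(C)ccc3c(=O)[nH]2)c1`), were tested in a functional assay on T47D cells (Homo sapiens) for cytotoxicity, read by MTT assay, with a stated time of 2 days (on this read-out lower numbers stand for stronger inhibition and higher numbers for weaker inhibition), and none returned a number. Compound 1 gives > 50000 nM as a limit of the assay, not a measured value. Compound 2 gives > 50000 nM as a limit too. Compound 3 gives > 50000 nM as a limit as well, so it has no number of its own and stands level with the other two on what can be read. Taken together, the evidence is the limit of > 50000 nM in this assay, at which 3 of the 3 values shown sit, and nothing more.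

Compound 4 (`Cc1ccc2c(=O)[nH]c(-c3cccc(C(F)(F)F)c3)nc2c1`) has not been measured yet. It differs from compound 3 by one group, trifluoromethyl in place of methoxy on an aromatic carbon and in words this is trifluoromethyl in place of methoxy on an aromatic carbon. Within the data shown here, the one measured step that bears on this swap is a step that the two limits leave unreadable from compound 1 to compound 3 and it offers no size to carry over. Compound 3 reports > 50000 nM as a limit, so no step beyond the scatter is expected in this assay and another limit is the likeliest result. The expected step runs a number no higher from compound 3 to compound 4 (the limit leaves the size open) in this estimate. For compound 4 the estimated value is 50000 nM with 20000 nM to 100000 nM as the expected range.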

Compound 4, half-maximal inhibitory concentration: > 50000 nM
Compound 4: a limit, no number (the forecaster's own chance of this, stated with the estimate: 75%); the middle value sits exactly at the limit.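

Compound 4 returns only a limit in this assay, as do compound 1 and compound 3, so no step among these three compounds can be read. The compounds shown leave open how far each one lies from that limit, and whether any change to the shared core would give a measurable value, as all that can be said is this: the limit of > 50000 nM in this assay, at which 4 of the 4 values shown sit.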